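Chloro in place of methyl on the benzoic acid ring

The source may hold more compounds than are shown below. What is called first, only, known or untested is meant among the compounds shown, and "the series" means these compounds.

Among the measured compounds shown here, compound 1 `Cc1ccc(C(=O)O)cc1-c1cccc(COc2ccc3c(c2)CN(C2CCCC2)C3=O)c1` gives 2% in an ADME assay on microsomes from liver (Rattus norvegicus) for metabolic stability, read by LC-MS, with a stated time of 1 h, at 37 degrees C, tested at 4 uM (on this read-out lower numbers stand for a less stable compound and higher numbers for a more stable compound), the lowest of the three numbers measured so far. Compound 2 `O=C(O)c1cc(-c2cccc(-c3ccc4c(c3)CN(C3CCCC3)C4=O)c2)ccc1Cl` gives 70% and compound 3 `O=C(O)c1cc(-c2cccc(COc3ccc4c(=O)n(CC5CC5)sc4c3)c2)ccc1Cl` gives 75%; both stand well above compound 1, beyond the scatter. Compound 4 `O=C(O)c1ccc(Cl)c(-c2cccc(COc3ccc4c(c3)CN(C3CCCC3)C4=O)c2)c1` has not been measured. It differs from compound 1 by chloro in place of methyl on an aromatic carbon, the rest of the shared core unchanged. For the measured compounds named here, no measured pair shows this exact change, so its size is uncertain; compounds 2 and 3 both carry a chloro and give high values, yet each differs from compound 1 in more than this one place. The step is expected to be an increase, a number 33 percentage points higher from compound 1 to compound 4 (beyond the scatter). Compound 4 is therefore expected to give 35%, within 5% to 75%.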

Compound 4, percent of the compound remaining: 15%
For compound 4 the middle estimate is 20 percentage points above the measured one; measured number inside the range.
By their numbers in this assay, from the lowest: compound 1; then compound 4; then compounds 2 and 3 (each within the scatter of the next).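

Chloro in place of methyl on this aromatic carbon, ortho to a large group and para to a carboxy group, gives a number 13 percentage points higher from compound 1 to compound 4 (beyond the scatter) in this assay. Among the compounds shown here, this is the first reading of the series in which a single place changes, and it shows a real but modest gain, with compound 4 still at 15%. Nothing measured here speaks to what lies behind the step. On these data alone, whether fluoro, methoxy or a nitrile at this position would give a larger step remains open. So does whether the change from methyl to chloro gives a step of this size on another core.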